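Arylation of the Thiosemicarbazone Nitrogen in Compound 1

A few compounds are considered here, and "the series" means these few. Any claim that something is new, unique, unknown or untested is made for them only; others in the source may bear on it.

Compound 1 `NC(=S)N/N=C/c1ccc2ccccc2n1` is a thiosemicarbazone whose terminal nitrogen carries only hydrogen. In a functional assay on SGC-7901 cells (Homo sapiens) for antiproliferative activity, read by sulforhodamine B assay, with a stated time of 72 h (a lower number here means a stronger inhibitor, a higher number a weaker inhibitor), compound 1 gives 32700 nM, the higher of the two numbers shown. Compound 3 `CN(C)C(=S)N/N=C/c1cnc2ccccc2n1`, which carries two methyl groups on that nitrogen and a different core, gives 170 nM in this assay, a far lower number than compound 1 and well beyond the scatter. Compound 2 `NC(=S)N/N=C/c1cc2ccccc2s1` reaches only a limit of this assay, > 100000 nM, and that limit is the one noted as the limit of > 100000 nM in this assay, at which 1 of the 3 values shown sits.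

Compound 4 `COc1ccc(NC(=S)N/N=C/c2ccc3ccccc3n2)cc1` differs from compound 1 in one place: 4-methoxyphenyl in place of hydrogen on an amide-type nitrogen. Among the measured compounds shown here, no pair of measured compounds isolates this change; compound 3 differs from compound 1 both at that nitrogen and in its core, so their two values show only that a substituted nitrogen goes with the lower number. Compound 4 is therefore expected to give a lower number than compound 1, with an expected step of an 11-fold lower number from compound 1 to compound 4 (1.04 log units; beyond the scatter) in this assay. The estimate for compound 4 is 3000 nM, in the range 400 nM to 20000 nM.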

Compound 4, half-maximal inhibitory concentration: 89600 nM
Compound 4: middle estimate off by 30-fold (1.48 log units), on the low side, outside the stated range (above it).
By their numbers in this assay, from the lowest: compound 3; then compound 1; then compound 4. At a limit, above all of these: compound 2.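

Placing 4-methoxyphenyl on the amide-type nitrogen, whose other neighbour is the thiocarbonyl carbon, gives in this assay a 2.7-fold higher number from compound 1 to compound 4 (0.44 log units; beyond the scatter), the only step shown that changes this nitrogen while the core stays fixed. On the core of compound 1, then, substitution at this nitrogen does not by itself go with a lower number, and the low value of compound 3 cannot be credited to such substitution alone. Nothing measured here gives a reason for this step.

As far as these compounds go, it remains open whether a single methyl, the two methyl groups of compound 3, an unsubstituted phenyl or a morpholine ring at this nitrogen would lower the number on the core of compound 1. Also open, from the compounds shown here alone, is whether 4-methoxyphenyl would raise the number on any other core.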